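A few compounds are considered here, and "the series" means these few. Any claim that something is new, unique, unknown or untested is made for them only; others in the source may bear on it.

Working notes on the series. The shared core is that of compound 1 `COC(=O)c1cc(OCC(=O)[C@H](CC(=O)O)NC(=O)[C@@H](NC(=O)COc2cccc3ccccc23)C(C)C)no1`. Going by the values given here, in a functional assay on Jurkat cells (Homo sapiens) for inhibition (on this read-out lower numbers stand for stronger inhibition and higher numbers for weaker inhibition), compound 1 gives 71000 nM; this is the only plain number in the set, so compound 1 stands as the sole reference point. Compound 2 `CC(C)[C@H](NC(=O)COc1cccc2ccccc12)C(=O)N[C@@H](CC(=O)O)C(=O)CSc1nc(-c2ccccc2)c(-c2ccccc2)[nH]1` carries a different end group on that core. In this assay compound 2 returns only a limit, > 200000 nM, not a number. That is the limit of > 200000 nM in this assay, at which 1 of the 2 values shown sits, so the two values shown span from a weak number to no number at all.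

Compound 3 `CC(C)[C@H](NC(=O)COc1cccc2ccccc12)C(=O)N[C@@H](CC(=O)O)C(=O)CSc1nc(-c2ccccc2)cs1` is not yet measured. It differs from compound 1 by (4-phenyl-1,3-thiazol-2-yl)sulfanyl in place of (5-(methoxycarbonyl)-1,2-oxazol-3-yl)oxy on a saturated chain carbon bound to a carbonyl carbon. Among the compounds with values here, no measured pair differs in a single place, so no step size can be read off directly. Within the data shown here, the only guide is that compound 2, which likewise carries a sulfanyl-linked group at that place, sits at the limit in this assay. A move toward weaker inhibition is therefore expected, with a real chance that this assay again reports only a limit. For compound 3 the estimate is 150000 nM, within 50000 nM to 400000 nM. The expected step is a 2.1-fold higher number from compound 1 to compound 3 (0.32 log units; beyond the scatter).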

Compound 3, half-maximal inhibitory concentration: > 200000 nM
Compound 3 gave a limit, no number; the forecaster's own chance of this, stated with the estimate: 40%; at least 1.3-fold (0.12 log units) between middle value and limit.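

In this assay the change gives an at least 2.8-fold higher number from compound 1 to compound 3 (0.44 log units; beyond the scatter), and this step is a bound rather than a measured size, as the value of compound 3 is a limit and not a number. Going by these compounds alone, this is the first step that can be read at this position, on a saturated chain carbon bound to a carbonyl carbon, and it shows that (4-phenyl-1,3-thiazol-2-yl)sulfanyl does not keep even the weak inhibition seen with (5-(methoxycarbonyl)-1,2-oxazol-3-yl)oxy. Both sulfanyl-linked compounds, compound 2 and compound 3, now sit at the limit, leaving compound 1 as the only compound with a plain number: the limit of > 200000 nM in this assay, at which 2 of the 3 values shown sit.

Steps involving only limits cannot be read, so nothing orders compound 2 and compound 3, and the true distance from compound 1 stays unknown. The change replaces the linking atom and the ring with its substituent all at once, so a (4-phenyl-1,3-thiazol-2-yl)oxy group, or a carboxylic acid in place of the methyl ester on the oxy-linked ring of compound 1, would be needed to separate these parts.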